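Hydroxy amide side chain: cyclopropyl to phenyl swap

This account rests on a few compounds, and the source may have more. Where it says the series, first, only, none or still open, it means among the compounds named here.

Of the compounds shown here, three of the shared core have been measured in a functional assay on a cell-free system (plasma, Homo sapiens), with a stated time of 3 min; a lower number here means a stronger inhibitor, a higher number a weaker inhibitor. Compound 1 `CC1(C[C@@H](O)C(=O)N2C[C@H]3C[C@H]3[C@H]2C(=O)NCc2cc(Cl)ccc2-n2cnnn2)CC1` gives 500 nM in this assay, the low end of the set. Compound 3 `CCCC[C@@H](O)C(=O)N1[C@@H]2C[C@@H]2C[C@H]1C(=O)NCc1cc(Cl)ccc1-n1cnnn1` gives 870 nM, a value within the scatter of compound 1. Compound 2 `CC(C)(C)C[C@@H](O)C(=O)N1NCC[C@H]1C(=O)NCc1cc(Cl)ccc1-n1cnnn1` gives 1300 nM, a gap to compound 1 that lies beyond the scatter. Going by the values given here, no step between two measured compounds differing in a single place is available.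

Compound 4 `O=C(NCc1cc(Cl)ccc1-n1cnnn1)[C@@H]1[C@@H]2C[C@@H]2CN1C(=O)[C@H](O)Cc1ccccc1` carries the change (phenyl in place of 1-methylcyclopropyl on a saturated chain carbon, two bonds along the chain from a carbonyl carbon and an oxygen on a saturated carbon). Among the compounds with values here, no measured pair informs this swap, so the expected step from compound 1 to compound 4, a 1.4-fold higher number from compound 1 to compound 4 (0.15 log units; within the scatter), is a small weakening, about at the edge of the scatter. Compound 4 is expected to give 700 nM in this assay, within 250 nM to 2000 nM.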

Compound 4, half-maximal inhibitory concentration: 970 nM
For compound 4 the middle estimate is 1.4-fold (0.14 log units) below the measured one; the range from low to high includes it.
By their numbers in this assay, from the lowest: compounds 1, 3, 4 and 2 (each within the scatter of the next, the first and the last beyond it).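

In this assay, the phenyl in place of 1-methylcyclopropyl on a saturated chain carbon gives a 1.9-fold higher number from compound 1 to compound 4 (0.29 log units; within the scatter), so at this place a six-membered aromatic ring of carbon only is tolerated in place of a three-membered non-aromatic one. Going by these compounds alone, this is the first single-place step, and it rests on one swap on one core. No measured evidence bears on this step.

Still open, from the compounds shown here alone, is how an amine or a carboxylic acid on this side chain would read in this assay. Going by these compounds, a longer chain ending in phenyl is equally open.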